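The compounds below may be only part of what the source reports. "The series", "measured", "known", "first", "only" and "open" are said of these compounds alone.

Measured in a functional assay on the whole organism for inhibition, with Cavia porcellus as the target; on this read-out higher numbers stand for an effect only at larger amounts of compound and lower numbers for an effect already at smaller amounts:
Compound 1 `COc1ccccc1OCC1SCCN1C(=O)CNC(C)=O`: 40 mg/kg
Compound 2 `C=CC(=O)N1CCSC1COc1ccccc1OC`: 74 mg/kg

Compound 2, at 74 mg/kg, stands level with compound 1 within the scatter. Compound 3 `COc1ccccc1OCC1SCCN1C(=O)CC(=O)O` carries carboxymethyl in place of vinyl on a carbonyl carbon. Going by the values given here, one measured step bears on this place, a 1.9-fold higher number from compound 1 to compound 2 (0.27 log units; within the scatter), and it did not exceed the scatter. Among the compounds with values here, with only this step as a guide, no step beyond the scatter is expected in this assay, although a single step is thin evidence. The expected change is a 1.5-fold lower number from compound 2 to compound 3 (0.19 log units; within the scatter). For compound 3 the estimated value is 48 mg/kg, with an expected range of 17 mg/kg to 135 mg/kg.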

Compound 3, dose for half-maximal effect: 20 mg/kg
Compound 3: middle estimate off by 2.4-fold (0.38 log units), on the high side, and the stated range covers the measured number.
By their numbers in this assay, from the lowest: compounds 3, 1 and 2 (each within the scatter of the next, the first and the last beyond it).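

Going by these compounds alone, on a carbonyl carbon whose other neighbour is an amide-type nitrogen in a ring, the change from vinyl to carboxymethyl gives the first step beyond the scatter in this assay, with a 3.7-fold lower number from compound 2 to compound 3 (0.57 log units; beyond the scatter). Set against acetamidomethyl, however, carboxymethyl shows a 2.0-fold lower number from compound 1 to compound 3 (0.30 log units; within the scatter), so only the two outer members of this short series separate. Nothing available explains the shift. The compounds shown leave open how an amine or the methyl ester of the carboxylic acid would read at this place, and whether a longer chain ending in a carboxylic acid would move the number further.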